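Methyl in Place of Fluoro: Expected Microsomal Clearance

This account rests on a few compounds, and the source may have more. Where it says the series, first, only, none or still open, it means among the compounds named here.

Compound 1 `COc1ccn2c(-c3ccc(NC(=O)c4ccc([N+](=O)[O-])o4)cc3)cnc2c1`: 74.2 mL.min-1.g-1
Compound 2 `COc1ccn2c(-c3ccc(NC(=O)c4ccc([N+](=O)[O-])o4)cc3F)cnc2c1`: 81.6 mL.min-1.g-1

In an ADME assay on microsomes from liver (Homo sapiens) for metabolic stability (a higher number here means faster removal of the compound, a lower number slower removal), compound 2 stands at 81.6 mL.min-1.g-1, and compound 1 stands at 74.2 mL.min-1.g-1, the two within the scatter of each other, as the step of a 1.1-fold higher number from compound 1 to compound 2 (0.04 log units; within the scatter) shows. Compound 3 `COc1ccn2c(-c3ccc(NC(=O)c4ccc([N+](=O)[O-])o4)cc3C)cnc2c1` differs from compound 2 by methyl in place of fluoro on an aromatic carbon. Among the compounds with values here, the only measured step concerns a different exchange and was within the scatter, so it gives little guidance here. A step of a 1.2-fold higher number from compound 2 to compound 3 (0.09 log units; within the scatter) is expected, toward a somewhat higher number that may not exceed the scatter. Compound 3 is estimated at 100 mL.min-1.g-1, between 50 mL.min-1.g-1 and 200 mL.min-1.g-1.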

Compound 3, intrinsic clearance in microsomes: 48.8 mL.min-1.g-1
Estimate against measurement, compound 3: 2.0-fold (0.31 log units) above; the whole stated range lies above it.
By their numbers in this assay, from the lowest: compounds 3, 1 and 2 (each within the scatter of the next).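

In this assay, methyl on this aromatic carbon, ortho to a large group, stays within the scatter of both earlier compounds: a 1.7-fold lower number from compound 2 to compound 3 (0.22 log units; within the scatter) for methyl in place of fluoro, and a 1.5-fold lower number from compound 1 to compound 3 (0.18 log units; within the scatter) for methyl in place of hydrogen. Hydrogen, fluoro and methyl at this position are therefore not told apart by this read-out. No measurement at hand bears on these steps. The compounds shown leave open whether an amine, a carboxylic acid or a longer chain at this position would give a step beyond the scatter.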